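The source may report more compounds than this note shows. Statements on the series, on what has been measured and on what is new or still open speak of the compounds shown alone.

Measured so far:
compound 1 `CCCCCCCCCCCCCCOC(=O)NC(=O)Oc1c(C(C)C)cccc1C(C)C`, 10 nM
compound 2 `CCCCCCCCCCCCCCCCOC(=O)NC(=O)Oc1c(C(C)C)cccc1C(C)C`, 50 nM
compound 3 `CCCCCCCCSC(=O)NC(=O)Oc1c(C(C)C)cccc1C(C)C`, 160 nM

All three values come from an assay on microsomes from intestine for inhibition of acyl-CoA:cholesterol acyltransferase (Oryctolagus cuniculus); a lower number here means a stronger inhibitor, a higher number a weaker inhibitor. Compound 1 and compound 2 share a core and differ in one place: ethyl in place of hydrogen on a saturated chain carbon, ten or more bonds along the chain from an oxygen next to a carbonyl group. That change gave a 5.0-fold higher number from compound 1 to compound 2 (0.70 log units; beyond the scatter). Compound 3 has the highest number of the three; its value is above that of compound 2 and further above that of compound 1. The difference between the core of compound 3 and the core of compound 1 is not broken down here.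

Compound 4 `CCCCCCCCCCSC(=O)NC(=O)Oc1c(C(C)C)cccc1C(C)C` has not been measured. It stands to compound 3 as compound 2 stands to compound 1: ethyl in place of hydrogen on a saturated chain carbon, eight bonds along the chain from a sulfur. The place is not the same word for word as in the earlier pair: there the change sat on a saturated chain carbon counted along the chain from an oxygen next to a carbonyl group, whereas here it sits on a saturated chain carbon counted along the chain from a sulfur, and the counts differ as well. It is therefore the same kind of change, not the same change, and the cores differ as well.

Only one observation of this kind of change is available, and it raised the number. For compound 4 in this assay a step in the same direction, but with a wide margin for the change of core and place, is expected: a 2.5-fold higher number from compound 3 to compound 4 (0.40 log units; beyond the scatter). Compound 4 is accordingly estimated at 400 nM, with a likely range from 120 nM to 1300 nM.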

Compound 4, half-maximal inhibitory concentration: 130 nM
Compound 4: the middle estimate sits 3.1-fold (0.49 log units) above what was measured; measured number inside the range.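

In this assay, ethyl in place of hydrogen on a saturated chain carbon does not carry over as a fixed step between these two cores: the same change on two cores in this assay, a 5.0-fold higher number (0.70 log units; beyond the scatter) from compound 1 to compound 2 and a 1.2-fold lower number (0.09 log units; within the scatter) from compound 3 to compound 4, 6.2-fold (0.79 log units) apart, beyond the scatter of two such steps

Eight bonds along the chain from a sulfur, the change gives a 1.2-fold lower number from compound 3 to compound 4 (0.09 log units; within the scatter), so no shift can be claimed for it on this core, and the rise seen in the earlier pair cannot be assumed to transfer. This does not show what sets the two steps apart, as the pairs differ both in the atom that carries the chain, a sulfur or an oxygen next to a carbonyl group, and in how far along the chain the change sits; with a single pair on each core, neither the core nor the chain length can be singled out.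

Open, going by these compounds, is how a tetradecyl chain on the sulfur would compare with compound 1 and how an octyl chain on the oxygen would compare with compound 3, two single-place comparisons that would bear directly on the role of the linking atom. Also open, on these data alone, is how a chain carrying an amine or a carboxylic acid would fare on either core.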